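A Methoxy Group Added Next in Line

A few compounds are considered here, and "the series" means these few. Any claim that something is new, unique, unknown or untested is made for them only; others in the source may bear on it.

Of the compounds shown here, three sharing one core have been measured in an assay on isolated protein (strain SPF) for antagonist activity at Alpha-1D adrenergic receptor (Rattus norvegicus); on this read-out lower numbers stand for tighter binding and higher numbers for weaker binding. Compound 1 `CCOc1ccccc1N1CCN(CC(O)COc2cc3c(cc2OC)COC(C)C3=O)CC1` gives 485 nM. Going by the values given here, compound 2 `COc1cc2c(cc1OCC(O)CN1CCN(C(=O)c3ccco3)CC1)C(=O)C(C)OC2` gives 1550 nM, and the only single-point step so far, a 3.2-fold higher number from compound 1 to compound 2 (0.50 log units; beyond the scatter), shows that exchanging the aryl group on the ring nitrogen for a carbonyl-linked heterocycle costs a modest amount of binding. Compound 3 `COc1cc2c(cc1OCC(O)CN1CCN(c3ccccc3)CC1)COC(C)C2=O` gives 621 nM, which places it second highest of the three numbers, close to compound 1 and well apart from compound 2.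

Compound 4 `COc1cc2c(cc1OCC(O)CN1CCN(c3ccccc3OC)CC1)COC(C)C2=O` has not yet been measured. It differs from compound 3 in one place: methoxy in place of hydrogen on an aromatic carbon. The new group sits on an aromatic carbon of a six-membered aromatic ring of carbon only, ortho to a large group. Among the compounds with values here, no measured step addresses this exact change. The step from compound 1 to compound 2 concerns a different part of the molecule. The values of compound 1 and compound 3 show that a 2-ethoxyphenyl and a plain phenyl on that nitrogen come out within the scatter of each other, which suggests a 2-methoxyphenyl should land in the same region.

The expected step is therefore a 1.2-fold lower number from compound 3 to compound 4 (0.09 log units; within the scatter), nothing beyond the scatter. Compound 4 is estimated at 500 nM, with a range from 250 nM to 1000 nM.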

Compound 4, dissociation constant: 2200 nM
Beside the measured number, compound 4's estimate is 4.4-fold (0.64 log units) below it; the measured number lies above the stated range.
By their numbers in this assay, from the lowest: compounds 1 and 3 (each within the scatter of the next); then compounds 2 and 4 (each within the scatter of the next).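

In this assay, the step from phenyl to 2-methoxyphenyl, a 3.5-fold higher number from compound 3 to compound 4 (0.55 log units; beyond the scatter), lies beyond the scatter, so methoxy in place of hydrogen on this aromatic carbon, ortho to a large group, is not a neutral change. Going by these compounds alone, the earlier compounds did not show this, as the only substituted aryl group among them was the 2-ethoxyphenyl of compound 1, which gives 485 nM, while compound 4, carrying 2-methoxyphenyl instead, gives 2200 nM, so these two closely named groups do not read alike here. Nothing measured in this set offers a reason for either the step or that gap.

The compounds shown carry only hydrogen, methoxy and ethoxy at this place, which leaves open how a fluorine atom, a hydroxyl group or a longer chain such as propoxy would read there. Also open is whether the methoxy step is particular to this aromatic carbon, since no compound shown carries a methoxy group on any other carbon of that ring.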